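Swapping one aromatic group on a shared core

The compounds below may be only part of what the source reports. "The series", "measured", "known", "first", "only" and "open" are said of these compounds alone.

Compound 1 (`COc1cc(C(=O)c2sc(-c3ccc(-c4ccccc4)cc3)cc2N)cc(OC)c1OC`) and compound 2 (`COc1cc(C(=O)c2sc(-c3ccc(Cl)c(Cl)c3)cc2N)cc(OC)c1OC`) share a core and differ in one group, and both were tested in a functional assay on FM3A cells (Mus musculus) for antiproliferative activity; on this read-out higher numbers stand for weaker inhibition and lower numbers for stronger inhibition. Compound 1 gives only a limit of the assay, > 10000 nM, and not a true number. Going by the values given here, compound 2 gives 400 nM, the only true number so far, which makes it the sole reference point.

Compound 3 (`CCOc1ccc(-c2cc(N)c(C(=O)c3cc(OC)c(OC)c(OC)c3)s2)cc1`) keeps the same core and carries 4-ethoxyphenyl in place of 3,4-dichlorophenyl, on an aromatic carbon next to the ring sulfur: 4-ethoxyphenyl in place of 3,4-dichlorophenyl on an aromatic carbon. Among the compounds with values here, no measured pair shows what this particular swap does, so any forecast is loose. Compound 3 still has one six-membered aromatic ring at this place, as does compound 2 at 400 nM, so a result in the same broad region is expected. A modest gain in potency is expected, with an estimated step of a 3.3-fold lower number from compound 2 to compound 3 (0.52 log units; beyond the scatter) in this assay. The estimate for compound 3 is 120 nM, with an expected range from 15 nM to 700 nM.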

Compound 3, half-maximal inhibitory concentration: 510 nM
Estimate against measurement, compound 3: 4.3-fold (0.63 log units) below; the measured number falls inside the stated range.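

In this assay, putting 4-ethoxyphenyl in place of 3,4-dichlorophenyl gives a 1.3-fold higher number from compound 2 to compound 3 (0.11 log units; within the scatter), so on this aromatic carbon next to the ring sulfur, two phenyl rings with quite different substituents cannot be told apart by this read-out. Ethoxy in place of phenyl on the same ring gives an at least 19-fold lower number from compound 1 to compound 3 (1.29 log units; beyond the scatter), a large step and the first sign that the group carried on this ring can decide between clear activity and none detectable within the tested range. The true size of that step stays unknown, since compound 1 gives a limit and not a number: the limit of > 10000 nM in this assay, at which 1 of the 3 values shown sits.

The compounds shown leave open how the length of the chain on the oxygen matters, for instance whether methoxy or a longer butoxy chain would behave like ethoxy. They also leave open whether a single chlorine, an amine or a carboxylic acid on this phenyl ring would stay in the range of compound 2 and compound 3 or fall away towards compound 1.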